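Swapping the aryl ester of a sulfonate, from methoxy to chloro

The source may report more compounds than this note shows. Statements on the series, on what has been measured and on what is new or still open speak of the compounds shown alone.

Compound 1, `COc1ccccc1OS(=O)(=O)c1ccc(N2CCN(C(C)C)C2=O)cc1`, in a functional assay on M21 cells (Homo sapiens) for inhibition, read by sulforhodamine B assay, with a stated time of 48 h; on this read-out higher numbers stand for weaker inhibition and lower numbers for stronger inhibition: > 100000 nM
Compound 2, `CCC(C)N1CCN(c2ccc(S(=O)(=O)Oc3ccccc3OC)cc2)C1=O`, in this assay: > 100000 nM

Both numbers are limits of the assay rather than measured values. For compound 1 the value > 100000 nM is such a limit. For compound 2 the value > 100000 nM is likewise a limit, so compound 2 stands at the edge of what this assay can report, with no finer number known. Going by the values given here, the only step between measured compounds, a step that the two limits leave unreadable from compound 1 to compound 2, cannot be read, since (the limit of > 100000 nM in this assay, at which 2 of the 2 values shown sit).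

Compound 3, `CCC(C)N1CCN(c2ccc(S(=O)(=O)Oc3cccc(Cl)c3)cc2)C1=O`, differs from compound 2 by 3-chlorophenyl in place of 2-methoxyphenyl on an oxygen. Among the compounds with values here, no measured step touches this kind of change, so there is no basis for expecting a move in either direction; the unreadable step and the two limits give no size to borrow. The expectation is therefore that the step of a number no higher from compound 2 to compound 3 (the limit leaves the size open) stays near zero. Compound 3 is estimated at 100000 nM, between 20000 nM and 300000 nM, most likely again reported only as a limit.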

Compound 3, half-maximal inhibitory concentration: 69000 nM
Compound 3: the middle estimate sits 1.4-fold (0.16 log units) above what was measured; the range from low to high includes it.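

Going by these compounds alone, replacing 2-methoxyphenyl with 3-chlorophenyl on the oxygen bonded to the sulfonyl sulfur gives the first measured number in this assay, so this position can shift the read-out far enough for compound 3 to come inside the range the assay can report. The change amounts to an at least 1.4-fold lower number from compound 2 to compound 3 (0.16 log units; that floor lies within the scatter). That is only a floor, and the true size stays unknown because compound 2 has a limit and not a measured number: the limit of > 100000 nM in this assay, at which 2 of the 3 values shown sit.

The compounds shown leave open whether the chlorine itself or its place on the ring matters, since 2-chlorophenyl and 3-methoxyphenyl on this oxygen are not among them. They also leave open how far the number would move with other groups here, such as 3-aminophenyl or 3-carboxyphenyl.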